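Pyridazinyl in place of methylpyridinyl: an expected drop in lipophilicity

This account rests on a few compounds, and the source may have more. Where it says the series, first, only, none or still open, it means among the compounds named here.

Measured compounds:
compound 1, `Cc1ccc([C@@H](C)Oc2cc3onc(CCC(=O)O)c3cc2Cl)nc1`, 2.42
compound 2, `Cc1ccnc([C@@H](C)Oc2cc3oc(=O)n(CCC(=O)O)c3cc2Cl)c1`, 2.15
compound 3, `CCc1cc2oc(=O)n(CCC(=O)O)c2cc1Cl`, 1.94

Of the compounds shown here, three have been read in a physicochemical assay for lipophilicity, read by HPLC, at pH 7.4; a higher number here means a more lipophilic compound, a lower number a more polar compound. Compound 1 `Cc1ccc([C@@H](C)Oc2cc3onc(CCC(=O)O)c3cc2Cl)nc1` gives 2.42, compound 2 `Cc1ccnc([C@@H](C)Oc2cc3oc(=O)n(CCC(=O)O)c3cc2Cl)c1` gives 2.15, and compound 3 `CCc1cc2oc(=O)n(CCC(=O)O)c2cc1Cl` gives 1.94. Compound 2 sits second highest of the three numbers; its nearest neighbour is compound 3, whose value lies a little lower, and its furthest is compound 1, whose value lies a little higher, yet both of these gaps fall within the scatter of this assay, so no order among the three can be claimed. Among the measured compounds shown here, no two of the measured compounds differ in a single place, so no measured step is available.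

The unmeasured compound 4 `C[C@@H](Oc1cc2oc(=O)n(CCC(=O)O)c2cc1Cl)c1cccnn1` differs from compound 2 in one place: pyridazin-3-yl in place of 4-methylpyridin-2-yl on a saturated chain carbon bound to an oxygen on an aromatic ring and a saturated chain carbon. A group of seven heavy atoms with one hydrogen-bond acceptor leaves, and a group of six heavy atoms with two hydrogen-bond acceptors enters. In this assay this change is expected to lower the number by a step beyond the scatter, a number 0.95 log units lower from compound 2 to compound 4 (beyond the scatter). Compound 4 is therefore estimated at 1.2, within a range from 0.6 to 1.8.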

Compound 4, distribution coefficient: 0.83
Compound 4: middle estimate off by 0.37 log units, on the high side; the measured number falls inside the stated range.
By their numbers in this assay, from the lowest: compound 4; then compounds 3, 2 and 1 (each within the scatter of the next, the first and the last beyond it).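

Pyridazin-3-yl in place of 4-methylpyridin-2-yl gives, in this assay, a number 1.32 log units lower from compound 2 to compound 4 (beyond the scatter), and this is the only step in the set that isolates a single place, since the earlier compounds offered no such pair. It shows that the group on this saturated chain carbon, bound to an oxygen on an aromatic ring, can by itself move the number by a large amount, whereas the earlier values lay within the scatter of their neighbours and could not show what any one position contributes. No measurement shown here explains the size of this step, and none ties it to a particular feature of the entering or leaving group.

Among the compounds shown here, the single swap removes the methyl group and changes the ring at once, so the step cannot be divided between those two changes, and pyridin-2-yl without its methyl group or a methyl-bearing pyridazinyl group would be needed to separate them. On these data alone, whether the same swap gives a step of similar size on the core of compound 1 also remains open.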